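A few compounds are considered here, and "the series" means these few. Any claim that something is new, unique, unknown or untested is made for them only; others in the source may bear on it.

The measured compounds, each with its result in a functional assay on MT2 cells (Homo sapiens) for antiproliferative activity, read by MTT assay, with a stated time of 72 h; on this read-out lower numbers stand for stronger inhibition of growth and higher numbers for weaker inhibition of growth:

Compound 1, `COc1ccc(NC(=O)COc2ccc3oc(-c4ccccc4)cc(=O)c3c2)cc1` — compound 1 gives 3010 nM.
Compound 2, `O=C(COc1ccc2oc(-c3ccccc3)cc(=O)c2c1)Nc1ccc(-c2ccccc2)cc1` — compound 2 gives > 10000 nM, which is a limit of the assay rather than a number.
Compound 3, `COc1ccc(NC(=O)COc2ccc3c(=O)c(-c4ccccc4)coc3c2)cc1` — compound 3 gives 4550 nM.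

All three carry an amide-linked chain joining a substituted aromatic ring to a larger ring system. Compound 1 and compound 3 are built from the same atoms joined differently; the difference between the two cores is not broken down here. In this assay compound 3 and compound 1 give numbers that lie within the usual scatter of each other, so no order between them can be read.

From compound 1 to compound 2 the change is phenyl in place of methoxy on an aromatic carbon. The step this produced was an at least 3.3-fold higher number from compound 1 to compound 2 (0.52 log units; beyond the scatter). Its size is known only as a lower bound because of the limit of > 10000 nM in this assay, at which 1 of the 3 values shown sits.

Compound 4, `O=C(COc1ccc2c(=O)c(-c3ccccc3)coc2c1)Nc1ccc(-c2ccccc2)cc1`, has not yet been measured. It differs from compound 3 by phenyl in place of methoxy on an aromatic carbon, the same change, at the same place, as from compound 1 to compound 2. Resting on compound 3 at 4550 nM and on the step of an at least 3.3-fold higher number from compound 1 to compound 2 (0.52 log units; beyond the scatter), the expected change is estimated as a 3.3-fold higher number from compound 3 to compound 4 (0.52 log units; beyond the scatter). Compound 4 is therefore estimated at 15000 nM, most likely between 8000 nM and 40000 nM, and it may well be reported as a limit rather than a number.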

Compound 4, concentration for 50% growth inhibition: > 10000 nM
Compound 4: no number, only a limit; the forecaster's own chance of this, stated with the estimate: 75%; the middle value lies beyond the limit too.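

In this assay compound 4 gives > 10000 nM as a limit of the assay and not a number.

Phenyl in place of methoxy on an aromatic carbon gives an at least 2.1-fold higher number from compound 3 to compound 4 (0.34 log units; beyond the scatter) and so weakens inhibition of growth on this core too, which means the direction of the change carries over from the core of compound 1 to the core of compound 3, while its size on each core stays unsettled: the same change on two cores in this assay, an at least 3.3-fold higher number (0.52 log units; beyond the scatter) from compound 1 to compound 2 and an at least 2.1-fold higher number (0.34 log units; beyond the scatter) from compound 3 to compound 4; the limit leaves it open whether they differ

What cannot be said is how far growth inhibition falls on either core, or whether one core tolerates phenyl better than the other, because compound 2 and compound 4 both end at the same limit rather than at a number: the limit of > 10000 nM in this assay, at which 2 of the 4 values shown sit.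

The compounds shown leave open how other groups at this aromatic carbon would behave, for example a single fluorine atom, a hydroxyl, an amine or a carboxylic acid, and whether any of them would give stronger inhibition of growth than methoxy on either core. They also leave open what a longer chain between the amide and the core would do, and whether the two cores would still behave alike with such a chain in place.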